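Replacing Ethyl with Thiophen-2-yl on the Carbonyl

The source may report more compounds than this note shows. Statements on the series, on what has been measured and on what is new or still open speak of the compounds shown alone.

Three compounds share one core and differ only in the group on the carbonyl carbon of the amide. Compound 1 `CCCC(=O)Nc1ccc(N2CCN(c3ccc(OC[C@@H]4CO[C@@](Cn5cncn5)(c5ccc(Cl)cc5Cl)O4)cc3)CC2)cc1` carries propyl there, compound 2 `CCC(=O)Nc1ccc(N2CCN(c3ccc(OC[C@@H]4CO[C@@](Cn5cncn5)(c5ccc(Cl)cc5Cl)O4)cc3)CC2)cc1` ethyl, and compound 3 `O=C(Nc1ccc(N2CCN(c3ccc(OC[C@@H]4CO[C@@](Cn5cncn5)(c5ccc(Cl)cc5Cl)O4)cc3)CC2)cc1)c1ccco1` furan-2-yl. In a functional assay on A549 cells (Homo sapiens) for inhibition, read by MTT assay, with a stated time of 48 h (a higher number here means a weaker inhibitor, a lower number a stronger inhibitor), compound 1 gives 2990 nM, compound 2 gives 2550 nM and compound 3 gives 10500 nM. Compound 2 thus shows the lowest of the three numbers, but a 1.2-fold lower number from compound 1 to compound 2 (0.07 log units; within the scatter) lies within the scatter, so compound 1 and compound 2 cannot be told apart; only compound 3 stands clearly apart, through a 3.5-fold higher number from compound 1 to compound 3 (0.55 log units; beyond the scatter) and a 4.1-fold higher number from compound 2 to compound 3 (0.61 log units; beyond the scatter).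

Compound 4 `O=C(Nc1ccc(N2CCN(c3ccc(OC[C@@H]4CO[C@@](Cn5cncn5)(c5ccc(Cl)cc5Cl)O4)cc3)CC2)cc1)c1cccs1` is not yet measured. It differs from compound 2 by thiophen-2-yl in place of ethyl on a carbonyl carbon. The measured step that bears most directly on this exchange is a 4.1-fold higher number from compound 2 to compound 3 (0.61 log units; beyond the scatter), where a five-membered aromatic ring with one hetero atom likewise took the place of ethyl, and a 3.5-fold higher number from compound 1 to compound 3 (0.55 log units; beyond the scatter) points the same way. Compound 4 is therefore expected to give a higher number than compound 2, estimated as a 3.5-fold higher number from compound 2 to compound 4 (0.55 log units; beyond the scatter). In this assay compound 4 is estimated at 9000 nM, within 4000 nM to 20000 nM.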

Compound 4, half-maximal inhibitory concentration: 4330 nM
Compound 4: middle estimate off by 2.1-fold (0.32 log units), on the high side; the range from low to high includes it.
By their numbers in this assay, from the lowest: compounds 2, 1 and 4 (each within the scatter of the next); then compound 3.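

Thiophen-2-yl on the carbonyl carbon does not repeat what furan-2-yl did: in this assay both a 1.7-fold higher number from compound 2 to compound 4 (0.23 log units; within the scatter) and a 1.4-fold higher number from compound 1 to compound 4 (0.16 log units; within the scatter) lie within the scatter, so the ring-bearing amide cannot be told apart from the two with open chains. A five-membered aromatic ring with one hetero atom therefore does not by itself raise the number at this position, and the choice of ring matters, as a 2.4-fold lower number from compound 3 to compound 4 (0.38 log units; beyond the scatter) lies beyond the scatter. Nothing available here accounts for the gap between the two rings.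

The compounds shown leave open how a six-membered ring such as phenyl or pyridin-2-yl, or an amine such as dimethylamino, would behave on this carbonyl carbon. They also leave open whether thiophen-3-yl would match thiophen-2-yl.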